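The source may report more compounds than this note shows. Statements on the series, on what has been measured and on what is new or still open speak of the compounds shown alone.

Of the compounds shown here, two have been measured in an assay for inhibition of Thromboxane-A synthase (Homo sapiens), using microsomes; a higher number here means a weaker inhibitor, a lower number a stronger inhibitor. Compound 1 `CC(C)(C)c1ccc(OC(C)(C)C2OCC(C/C=C\CCC(=O)O)C(c3cccnc3)O2)cc1` gives 280 nM. Compound 2 `CC(C)(Oc1ccccc1F)C1OCC(C/C=C\CCC(=O)O)C(c2cccnc2)O1` gives 45 nM, the lower of the two numbers; the step of a 6.2-fold lower number from compound 1 to compound 2 (0.79 log units; beyond the scatter) exchanged one aryl group for another on an oxygen on a saturated carbon of the shared core. Compound 3 `CC(C)(Oc1ccccc1[N+](=O)[O-])C1OCC(C/C=C\CCC(=O)O)C(c2cccnc2)O1` keeps the core of compound 2 and differs from it by nitro in place of fluoro on an aromatic carbon. Within the data shown here, no measured step swaps one small group for another on this aromatic ring, so the one step measured so far concerns a different kind of change and offers no direct guide. With nothing to point either way, the step of no change at the digits printed from compound 2 to compound 3 (within the scatter) is estimated to stay within the scatter, with no clear direction. Compound 3 is therefore expected to give about 45 nM, within a range from 15 nM to 150 nM.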

Compound 3, half-maximal inhibitory concentration: < 10 nM
Compound 3: only a limit was reported (the forecaster's own chance of this, stated with the estimate: 2%); middle value at least 4.5-fold (0.65 log units) away from the limit.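

In this assay, nitro in place of fluoro, on an aromatic carbon ortho to a large group, gives an at least 4.5-fold lower number from compound 2 to compound 3 (0.65 log units; beyond the scatter), so a change at this one place on the ring is enough to move the number beyond the scatter, which the earlier exchange of one whole aryl group for another could not show. Measured against the 4-(tert-butyl)phenyl group of the first compound, the 2-nitrophenyl group gives an at least 28-fold lower number from compound 1 to compound 3 (1.44 log units; beyond the scatter). Compound 3 is reported as a limit of the assay and not as a number: the limit of < 10 nM in this assay, at which 1 of the 3 values shown sits.

With only fluoro and nitro compared at this place, the compounds shown do not tell how an amine, a nitrile or a methoxy group would read here. They also leave open whether nitro would give a similar step on another aromatic carbon of this ring.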